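Working notes: one trifluoromethyl removed from compound 3

This account rests on a few compounds, and the source may have more. Where it says the series, first, only, none or still open, it means among the compounds named here.

The series is read in a functional assay on U-251 cells (Homo sapiens) for inhibition, read by sulforhodamine B assay, with a stated time of 48 h, tested at 0.01 uM; on this read-out lower numbers stand for a stronger effect and higher numbers for a weaker effect at the one concentration tested. Compound 1 `O=C(Nc1cccc(-n2cc(-c3ccncc3)c(-c3cc(O)cc(Cl)c3)n2)c1)Nc1ccc(Cl)c(C(F)(F)F)c1` gives 97%. Among the measured compounds shown here, compound 2 `O=C(Nc1cccc(-n2cc(-c3ccncc3)c(-c3cc(O)cc(Cl)c3)n2)c1)Nc1ccc(Cl)c(Cl)c1` gives 96%, and the step of a number 1 percentage points lower from compound 1 to compound 2 (within the scatter) is the only single-point step among the measured compounds. Compound 3 `COc1cc(Cl)cc(-c2nn(-c3cccc(NC(=O)Nc4cc(C(F)(F)F)cc(C(F)(F)F)c4)c3)cc2-c2ccncc2)c1` gives 96%. At the digits shown compound 3 is level with compound 2, and compound 1 lies within the scatter of both, so the three measured numbers do not separate from one another; all sit near the top of the read-out at the concentration tested.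

Compound 4 `COc1cc(Cl)cc(-c2nn(-c3cccc(NC(=O)Nc4cccc(C(F)(F)F)c4)c3)cc2-c2ccncc2)c1` is not yet measured. It differs from compound 3 in one place: hydrogen in place of trifluoromethyl on an aromatic carbon. For the measured compounds named here, no measured step removes a group altogether. Going by the values given here, the only step that bears on it is a number 1 percentage points lower from compound 1 to compound 2 (within the scatter), an exchange of one group for another on the same kind of ring, and that exchange moved nothing beyond the scatter. On that basis, and because the measured numbers for compound 1, compound 2 and compound 3 all lie within the scatter of each other, the expected step is a number 1 percentage points higher from compound 3 to compound 4 (within the scatter), none beyond the scatter. Compound 4 is therefore estimated at 97%, with a range from 89% to 103%.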

Compound 4, a percentage reported as activity, at one concentration (the size of the read-out at that concentration, not a potency): 95%
Estimate against measurement, compound 4: 2 percentage points above, and the stated range covers the measured number.
By their numbers in this assay, from the lowest: compounds 4, 2, 3 and 1 (each within the scatter of the next).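

In this assay, a number 1 percentage points lower from compound 3 to compound 4 (within the scatter), with hydrogen in place of trifluoromethyl on an aromatic carbon meta to a large group and meta to a trifluoromethyl group. Among the compounds shown here, this is the only step among the measured compounds that takes a group away rather than exchanging it for another: 4 heavy atoms leave, no heavy atom enters, and the read-out still does not separate the pair, so at this one concentration the second trifluoromethyl of compound 3 is not needed to hold the number at this level. No accompanying data bear on this result.

The compounds shown leave open whether a group of another kind at this place, such as an amine or a carboxylic acid, would give a step beyond the scatter, since only trifluoromethyl and hydrogen are compared here. They also leave open whether the same removal would read alike on the core of compound 1, which carries a hydroxyl where compound 3 carries a methoxy group, or at any other concentration.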